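Aryl swap at the ring nitrogen of a quinazoline-type core

A few compounds are considered here, and "the series" means these few. Any claim that something is new, unique, unknown or untested is made for them only; others in the source may bear on it.

Compound 1: `CCCCCCCCCCCCNc1nc(SCc2ccc(C(F)(F)F)cc2)nc2ccccc12` gives > 50000 nM in a functional assay on MDA-MB-231 cells (Homo sapiens) for cytotoxicity, read by MTT assay, with a stated time of 72 h; on this read-out higher numbers stand for weaker inhibition and lower numbers for stronger inhibition.
Compound 2: `CCOc1ccccc1Nc1nc(SCc2ccc(C(F)(F)F)cc2)nc2ccccc12` gives > 50000 nM in this assay.
Compound 3: `FC(F)(F)c1ccc(CSc2nc(Nc3cccc(C(F)(F)F)c3)c3ccccc3n2)cc1` gives 11100 nM in this assay.
Compound 4: `FC(F)(F)c1ccc(CSc2nc(Nc3ccc(C(F)(F)F)cc3)c3ccccc3n2)cc1` is not yet measured in this assay.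

Compound 2 stands at a limit of this assay rather than at a number. The same limit is shared by compound 1, so two of the three measured values sit at the limit of > 50000 nM in this assay, at which 2 of the 3 values shown sit, and only compound 3 carries a real number. Compound 4 differs from compound 2 by 4-(trifluoromethyl)phenyl in place of 2-ethoxyphenyl on a nitrogen on an aromatic ring. For the measured compounds named here, the only measured step that touches this change is the one from compound 2 to compound 3, which also replaces the 2-ethoxyphenyl by a trifluoromethyl-bearing phenyl, and it reads an at least 4.5-fold lower number from compound 2 to compound 3 (0.65 log units; beyond the scatter). Compound 3 and compound 4 differ only in where the trifluoromethyl sits on the phenyl, and no step between them is shown, so their two values can only be compared once compound 4 is measured. The expectation is therefore a step of similar size and direction, an at least 3.3-fold lower number from compound 2 to compound 4 (0.52 log units; beyond the scatter), away from the limit. Compound 4 is expected to give about 15000 nM in this assay, within a range from 5000 nM to 50000 nM.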

Compound 4, half-maximal inhibitory concentration: 5460 nM
For compound 4 the middle estimate is 2.7-fold (0.44 log units) above the measured one; measured number inside the range.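

A second trifluoromethyl-bearing phenyl on the ring nitrogen now gives a measured number in this assay, so the drop seen earlier is not confined to a single aryl group: 4-(trifluoromethyl)phenyl in place of 2-ethoxyphenyl gives an at least 9.1-fold lower number from compound 2 to compound 4 (0.96 log units; beyond the scatter). For the compounds shown here, compound 2 itself holds only a limit, so this step marks a minimum and not a true size: the limit of > 50000 nM in this assay, at which 2 of the 4 values shown sit. For the first time the place of the trifluoromethyl on the phenyl can also be read, as a 2.0-fold lower number from compound 3 to compound 4 (0.31 log units; beyond the scatter), a modest step that favours the 4-(trifluoromethyl)phenyl group over the 3-(trifluoromethyl)phenyl group.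

As far as these compounds go, whether the trifluoromethyl group itself is needed remains open, since an unsubstituted phenyl, a 4-chlorophenyl or a 4-(dimethylamino)phenyl on this nitrogen would be required to separate its contribution from that of the aryl ring. Also open, from the compounds shown here alone, is whether the same order of the two trifluoromethyl isomers would hold if the 4-(trifluoromethyl)benzyl group on the sulfur gave way to a plain benzyl or a carboxylic acid-bearing chain.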